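This account rests on a few compounds, and the source may have more. Where it says the series, first, only, none or still open, it means among the compounds named here.

Among the compounds with values here, compound 1 `CC(c1ccc(-c2ccccc2)c(F)c1)c1nnc2n1N=C(c1ccc(Cl)cc1)CS2` is one of three compounds measured in a functional assay on HepG2 cells (Homo sapiens) for inhibition, read by sulforhodamine B assay, with a stated time of 72 h; a lower number here means a stronger inhibitor, a higher number a weaker inhibitor. In this assay compound 1 gives 6700 nM. Compound 2 `CC(C)Cc1ccc(C(C)c2nnc3n2N=C(c2ccc(OC(F)(F)F)cc2)CS3)cc1` gives 9700 nM, a number that lies within the usual scatter of the number for compound 1, so the two cannot be ranked against each other. Compound 3 `COc1ccc2cc(C(C)c3n[nH]c(=S)n3N)ccc2c1`, built on a different core, gives 40000 nM, a number clearly higher than that of compound 1, beyond the scatter. Within the data shown here, compound 1 thus has a number that no other measured compound undercuts, with compound 2 close beside it.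

Compound 4 `CC(c1ccc(-c2ccccc2)c(F)c1)c1nnc2n1N=C(c1ccc(F)cc1)CS2` has not yet been measured. It differs from compound 1 in one place: fluoro in place of chloro on an aromatic carbon. Both groups sit para to a large group on the same six-membered carbon ring; only one halogen atom is swapped for another. No pair of measured compounds shows this exact swap, so no step between measured compounds can be read from the numbers shown.

A swap of one halogen for another at this position is expected to move the number only a little, if at all, and the step from compound 1 to compound 4 is estimated as a 1.2-fold higher number from compound 1 to compound 4 (0.08 log units; within the scatter), probably not beyond the scatter. Compound 4 is therefore expected to give about 8000 nM, within a range from 3500 nM to 18000 nM.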

Compound 4, half-maximal inhibitory concentration: 5100 nM
Compound 4: middle estimate off by 1.6-fold (0.20 log units), on the high side, within the range that was stated.
By their numbers in this assay, from the lowest: compounds 4, 1 and 2 (each within the scatter of the next); then compound 3.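

Replacing chloro with fluoro on this aromatic carbon gives a 1.3-fold lower number from compound 1 to compound 4 (0.12 log units; within the scatter) in this assay, so compound 1 and compound 4 cannot be ranked against each other. The earlier compounds shown here differed from one another in more than one place and could not show what this position does alone; this pair isolates a single atom, and the change from 4-chlorophenyl to 4-fluorophenyl leaves no readable difference in the number. No separate measurement here bears on why these two halogens read alike, so the result stands as a plain observation and offers no explanation.

The compounds shown do not tell whether a group of a different kind at this position, such as an amine, a carboxylic acid or a longer chain, would also leave the number where it is, or would move it clearly up or down. They also leave open whether the same halogen swap would read the same way in compounds that differ from compound 1 elsewhere in the structure.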